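The source may hold more compounds than are shown below. What is called first, only, known or untested is meant among the compounds shown, and "the series" means these compounds.

Measured so far in a functional assay on cardiac atrium for agonist activity at histamine H2 receptor (Cavia porcellus); a higher number here means a more potent compound, by a factor of ten per unit of this negative logarithm, a lower number a less potent compound:
- compound 1 `N=C(NCCCc1c[nH]cn1)NCCC(c1ccccc1)c1ccccn1`: 7.39
- compound 2 `N=C(NCCCc1c[nH]cn1)NCCC(c1cc(F)cc(F)c1)c1ccccn1`: 8.05

Compound 2 stands highest of the two numbers in this assay, and its nearest neighbour is compound 1, which gives 7.39; the gap between them, a number 0.66 log units higher from compound 1 to compound 2 (beyond the scatter), lies beyond the scatter. The two compounds share the same core and differ only in the aryl group on the saturated chain carbon bound to an aromatic carbon and a saturated chain carbon.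

Compound 3 `N=C(NCCCc1c[nH]cn1)NCCC(c1ccccn1)c1cccs1` is not yet measured in this assay. It differs from compound 2 in one place: thiophen-2-yl in place of 3,5-difluorophenyl on a saturated chain carbon bound to an aromatic carbon and a saturated chain carbon. Within the data shown here, no measured step replaces 3,5-difluorophenyl by thiophen-2-yl, so the only step that bears on this change is a number 0.66 log units higher from compound 1 to compound 2 (beyond the scatter), which shows that swapping the aryl group at this position moves the number by a modest but real amount. With the 3,5-difluorophenyl group of compound 2 leaving and no comparison for thiophen-2-yl in hand, the expectation for compound 3 is a number between those of compound 1 and compound 2, nearer to compound 1.

The estimated step is a number 0.45 log units lower from compound 2 to compound 3 (beyond the scatter), a modest decrease from compound 2 to compound 3. For compound 3 the estimate in this assay is 7.6, within a range of 7.1 to 8.2.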

Compound 3, negative logarithm of the half-maximal effective concentration: 7.16
Compound 3: middle estimate off by 0.44 log units, on the high side, within the range that was stated.
By their numbers in this assay, from the lowest: compounds 3 and 1 (each within the scatter of the next); then compound 2.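

In this assay, the aryl position on the saturated chain carbon bound to an aromatic carbon and a saturated chain carbon now has three readings, and the step of a number 0.89 log units lower from compound 2 to compound 3 (beyond the scatter) shows that thiophen-2-yl does not hold the level reached with 3,5-difluorophenyl. The step of a number 0.23 log units lower from compound 1 to compound 3 (within the scatter) shows that thiophen-2-yl and phenyl cannot be told apart here, so exchanging the six-membered carbon ring for a five-membered ring with one hetero atom has no readable effect, and of these three groups only 3,5-difluorophenyl stands out, with compound 2 the most potent of the three. No measurement at hand accounts for why this group stands apart from the other two.

As far as these compounds go, whether both fluorine atoms are required remains open, as does whether a single fluorine, two chlorine atoms or a methoxy group on the phenyl ring would give the same reading. Also open, from the compounds shown here alone, is how thiophen-2-yl would read with its own halogen substituents, such as a chlorine atom on the five-membered ring, and so whether the gain seen with fluorine carries over to that ring.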